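A few compounds are considered here, and "the series" means these few. Any claim that something is new, unique, unknown or untested is made for them only; others in the source may bear on it.

Measured in a functional assay on HUVEC cells (Homo sapiens) for antiproliferative activity, read by MTT assay, with a stated time of 24 h (a lower number here means a stronger inhibitor, a higher number a weaker inhibitor), each value below is a limit of the assay and not a number:

- compound 1 `C=CCc1cc(-c2ccccc2)ccc1O`: > 100000 nM
- compound 2 `C=CCc1cc(-c2ccc(F)cc2)ccc1O`: > 100000 nM
- compound 3 `C=CCc1cc(-c2ccc(OC)cc2)ccc1O`: > 100000 nM

Compound 3 therefore has only a limit, > 100000 nM, and shares it with the other two: all three sit at the limit of > 100000 nM in this assay, at which 3 of the 3 values shown sit.

Compound 4 `C=CCc1cc(-c2ccc(C(F)(F)F)cc2)ccc1O` carries trifluoromethyl in place of methoxy on an aromatic carbon, para to a large group: trifluoromethyl in place of methoxy on an aromatic carbon.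

The nearest measured changes are a step that the two limits leave unreadable from compound 1 to compound 2, a step that the two limits leave unreadable from compound 1 to compound 3 and a step that the two limits leave unreadable from compound 2 to compound 3. None of them has a readable size, so they point to no direction, and another limit seems the likeliest result in this assay.

The estimate implies a step that the limit leaves unreadable from compound 3 to compound 4, an expected step without firm direction.

Compound 4 is expected at about 120000 nM, within an estimated range of 40000 nM to 300000 nM.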

Compound 4, half-maximal inhibitory concentration: 74000 nM
Beside the measured number, compound 4's estimate is 1.6-fold (0.21 log units) above it, within the range that was stated.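

At this position, para to a large group, trifluoromethyl gives the first result that is a number and not a limit. Within the data shown here, in place of methoxy it gives an at least 1.3-fold lower number from compound 3 to compound 4 (0.13 log units; that floor lies within the scatter) and in place of fluoro it gives an at least 1.3-fold lower number from compound 2 to compound 4 (0.13 log units; that floor lies within the scatter) and in place of hydrogen it gives an at least 1.3-fold lower number from compound 1 to compound 4 (0.13 log units; that floor lies within the scatter) as the only readable steps here. The other three compounds remain at a limit, and the steps among them cannot be read: the limit of > 100000 nM in this assay, at which 3 of the 4 values shown sit.

On these data alone, how far the number would move with an amine or a carboxylic acid at this position stays open.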